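Acetylpiperidine in place of phenyl: solubility outlook

The source may report more compounds than this note shows. Statements on the series, on what has been measured and on what is new or still open speak of the compounds shown alone.

For the measured compounds named here, compound 3 `COc1cccc(NC(=O)c2nnn(Cc3ccccc3)c2N)c1` gives the only plain number in a physicochemical assay for solubility, read by nephelometry, at pH 7.4 (a lower number here means a less soluble compound, a higher number a more soluble compound), at 16000 nM. Compound 1 `COc1cccc(NC(=O)c2nnn(CC3CCNCC3)c2N)c1` returns a limit of the assay, > 250000 nM. Compound 2 `COc1cccc(NC(=O)c2nnn(Cc3ccc(SC)cc3)c2N)c1` likewise returns a limit, < 12000 nM. Compound 4 `COc1cccc(NC(=O)c2nnn(CC3CCN(C(C)=O)CC3)c2N)c1` differs from compound 3 by 1-acetylpiperidin-4-yl in place of phenyl on a saturated chain carbon bound to an aromatic nitrogen. The step that bears on this is an at least 15-fold lower number from compound 1 to compound 3 (1.19 log units; beyond the scatter), and an at least 20-fold lower number from compound 1 to compound 2 (1.31 log units; beyond the scatter) points the same way. The move from compound 3 to compound 4 runs back toward a saturated ring, yet with 1-acetylpiperidin-4-yl rather than piperidin-4-yl, so a higher number is expected, smaller than that step. Compound 4 is estimated at 60000 nM, with a range from 20000 nM to 200000 nM. This expected change amounts to a 3.8-fold higher number from compound 3 to compound 4 (0.57 log units; beyond the scatter).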

Compound 4, solubility: > 250000 nM
Compound 4: a limit, no number; the forecaster's own chance of this, stated with the estimate: 15%; at least 4.1-fold (0.61 log units) between middle value and limit.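

In this assay, 1-acetylpiperidin-4-yl on a saturated chain carbon bound to an aromatic nitrogen gives an at least 15-fold higher number from compound 3 to compound 4 (1.19 log units; beyond the scatter) and an at least 20-fold higher number from compound 2 to compound 4 (1.31 log units; beyond the scatter). The large gain over the aromatic groups therefore does not depend on keeping the hydrogen on the amine nitrogen in the ring, since compound 4 carries acetyl there. The step between compound 1 and compound 4 cannot be read because both sit at the same limit: the limit of > 250000 nM in this assay, at which 2 of the 4 values shown sit.

Going by these compounds, whether a saturated ring alone carries the gain remains open, and cyclohexyl would test this without any ring nitrogen. On these data alone, the outcome for a morpholine at this position also stays open.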